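Replacing trifluoromethyl by propyl on the chain

The compounds below may be only part of what the source reports. "The series", "measured", "known", "first", "only" and "open" are said of these compounds alone.

Measured in an assay on CHO cells for activation of soluble guanylate cyclase alpha1/beta1 complex (Homo sapiens), read by cGMP accumulation; a lower number here means that less compound is needed, a higher number that more compound is needed for the effect:
Compound 1 `CCCc1nn(-c2nc(N)c3c(n2)NC(=O)C3(C)C)c2ccc(Cl)cc12` gives 546000 nM.
Compound 2 `CC1(C)C(=O)Nc2nc(-n3nc(CCCC(F)(F)F)c4cc(Cl)ccc43)nc(N)c21` gives 117000 nM.
Compound 3 `CC1(C)C(=O)Nc2nc(-n3nc(CCC(F)(F)F)c4cc(Cl)ccc43)nc(N)c21` gives 87000 nM.

Compound 3 has the lowest number of the three, but one of the two steps toward it is small (a 1.3-fold lower number from compound 2 to compound 3 (0.13 log units; within the scatter)), while the other is clear (a 6.3-fold lower number from compound 1 to compound 3 (0.80 log units; beyond the scatter)). Compound 4 `CCCCCc1nn(-c2nc(N)c3c(n2)NC(=O)C3(C)C)c2ccc(Cl)cc12` differs from compound 3 by propyl in place of trifluoromethyl on a saturated chain carbon, two bonds along the chain from an aromatic carbon. Among the compounds with values here, two measured steps bear on this: a 6.3-fold lower number from compound 1 to compound 3 (0.80 log units; beyond the scatter), where trifluoromethyl replaced methyl at this very place, and a 4.7-fold lower number from compound 1 to compound 2 (0.67 log units; beyond the scatter), where trifluoromethyl was added further out. Both show that adding fluorine lowered the number, so taking it away is expected to raise it, by roughly a 4.0-fold higher number from compound 3 to compound 4 (0.60 log units; beyond the scatter). Compound 4 is therefore estimated at 350000 nM, within 100000 nM to 1500000 nM.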

Compound 4, half-maximal effective concentration: 90000 nM
For compound 4 the middle estimate is 3.9-fold (0.59 log units) above the measured one; the measured number lies below the stated range.
By their numbers in this assay, from the lowest: compounds 3, 4 and 2 (each within the scatter of the next); then compound 1.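

The step of a 1.0-fold higher number from compound 3 to compound 4 (0.01 log units; within the scatter) shows that pentyl does as well as 3,3,3-trifluoropropyl here, so fluorine is not needed to reach this number. The step of a 1.3-fold lower number from compound 2 to compound 4 (0.11 log units; within the scatter) likewise leaves the all-carbon chain level with the other fluorinated chain. The step of a 6.1-fold lower number from compound 1 to compound 4 (0.78 log units; beyond the scatter) shows that a longer chain without fluorine brings the same gain over compound 1 as the fluorinated chains.

From the compounds shown here alone, whether a still longer chain, or a chain ending in an amine or a carboxylic acid, would lower the number further stays open. Nothing measured here explains why these chains give such close values.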